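Swapping an amide for an ester at a nitro-bearing core

The source may hold more compounds than are shown below. What is called first, only, known or untested is meant among the compounds shown, and "the series" means these compounds.

The set comprises three measured compounds sharing a bicyclic core and one that awaits measurement. Compound 1 `NC(=O)c1nc2ccccn2c1[N+](=O)[O-]` carries a carbamoyl group and a nitro group. In a physicochemical assay for lipophilicity, measured as octanol-water partition (a higher number here means a more lipophilic compound, a lower number a more polar compound), compound 1 gives -0.569, the lowest of the three numbers. Compound 2 `Cc1cccc2nc(NC3CCCCC3)c([N+](=O)[O-])n12` gives 1.5 in this assay, and compound 3 `Cc1cccc2nc(C#N)c([N+](=O)[O-])n12` gives 1.13. Both of these sit beyond the scatter from compound 1, with compound 3 the nearer of the two and compound 2 the further.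

Compound 4 `CCOC(=O)c1nc2ccccn2c1[N+](=O)[O-]` differs from compound 1 in one place: ethoxy in place of amino on a carbonyl carbon. Cut one bond further out, the change reads carbamoyl to ethoxycarbonyl. Among the measured compounds shown here, no measured pair in this set shows such a change, so the size of the step cannot be read from a neighbour; what is known is that the group that leaves brings one hydrogen-bond donor and the ethoxy that enters brings one hydrogen-bond acceptor and two further carbons.

The step from compound 1 to compound 4 is expected to be an increase of about a number 1.37 log units higher from compound 1 to compound 4 (beyond the scatter) in this assay. Compound 4 is therefore estimated at 0.8, within a range from 0.3 to 1.4.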

Compound 4, partition coefficient: 1.05
Compound 4: middle estimate off by 0.25 log units, on the low side; the range from low to high includes it.
By their numbers in this assay, from the lowest: compound 1; then compounds 4 and 3 (each within the scatter of the next); then compound 2.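

In this assay, among the compounds shown here, the change of ethoxy in place of amino on a carbonyl carbon gives a number 1.62 log units higher from compound 1 to compound 4 (beyond the scatter) and is the first step in the set that can be read at a single place, so the size of a change at this position now rests on a measured pair. It shows that this position, a carbonyl carbon whose other neighbour is an aromatic carbon, can carry a large step when carbamoyl becomes ethoxycarbonyl, although this one pair cannot separate the loss of the hydrogen-bond donor on amino from the gain of the hydrogen-bond acceptor and carbons on ethoxy. Nothing further is available that would account for the size of this step.

The compounds shown leave open how a carboxylic acid, a methoxy group or a longer chain on the same carbonyl carbon would compare with amino and ethoxy, and so whether the step follows the length of the chain. They also leave open whether the same change would give a step of this size on a core carrying the methyl group of compounds 2 and 3.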